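The source may hold more compounds than are shown below. What is called first, only, known or untested is meant among the compounds shown, and "the series" means these compounds.

Two compounds of a shared core were examined in a functional assay on the whole organism (strain CD-1) with Mus musculus as the target, in the maximal electroshock model, with a stated time of 2 h; a higher number here means that more compound is needed for the effect, a lower number that less compound is needed. Compound 1 `Cc1cccc(N2CCN(C(=O)CN3C(=O)CC(C)(c4ccccc4)C3=O)CC2)c1` gave a minimum effective dose of 300 mg/kg in this assay. Compound 2 `COc1cccc(N2CCN(C(=O)CN3C(=O)CC(C)(c4ccccc4)C3=O)CC2)c1` differs from compound 1 only in the group on the amine nitrogen in a ring. In this assay compound 2 was reported as "not active" (no number reported), so no single number stands for compound 2 and its standing can only be described as inactive at the doses tried. Compound 3 `CC1(c2ccccc2)CC(=O)N(CC(=O)N2CCN(c3cccc(Cl)c3Cl)CC2)C1=O` has not been measured; it differs from compound 2 by 2,3-dichlorophenyl in place of 3-methoxyphenyl on an amine nitrogen in a ring. For the measured compounds named here, with no measured step in this assay to rest on, and with compound 2 without a number, the direction and size of the step cannot be predicted beyond the scatter. Compound 3 is estimated to give a minimum effective dose near 300 mg/kg in this assay, with a range from 100 mg/kg to 1000 mg/kg, and a real chance that only inactivity is reported.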

Compound 3, minimum effective dose: "not active" (no number reported)
Compound 3: no number reported; the estimate stays without a comparison.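

In this assay compound 3, like compound 2, was reported only as not active, so no step can be read between them. The compounds shown leave open how far the group on the amine nitrogen in a ring governs activity. No supporting evidence bears on this result.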